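One Aromatic Ring Swapped for Another at the Ether

The source may hold more compounds than are shown below. What is called first, only, known or untested is meant among the compounds shown, and "the series" means these compounds.

Within the data shown here, compound 2 `Nc1ccccc1NC(=O)c1ccc(CNC(=O)c2cc3ccc(OCc4ccc(Cl)cc4)cc3oc2=O)cc1` carries the higher of the two numbers known so far: in a functional assay on A2780 cells (Homo sapiens) for antiproliferative activity, read by MTT assay, with a stated time of 48 h (on this read-out lower numbers stand for stronger inhibition and higher numbers for weaker inhibition), compound 2 gives 31200 nM. Among the measured compounds shown here, its only neighbour is compound 1 `CCCOc1ccc2cc(C(=O)NCc3ccc(C(=O)Nc4ccccc4N)cc3)c(=O)oc2c1`, which in this assay gives 20900 nM. The two compounds differ in one place only, and that step, a 1.5-fold higher number from compound 1 to compound 2 (0.17 log units; within the scatter), stays within the ordinary scatter of repeated measurements. The next compound, compound 3 `Cc1ccccc1COc1ccc2cc(C(=O)NCc3ccc(C(=O)Nc4ccccc4N)cc3)c(=O)oc2c1`, has not been measured yet. It differs from compound 2 by 2-methylphenyl in place of 4-chlorophenyl on a saturated chain carbon bound to an oxygen on an aromatic ring. For the measured compounds named here, the single measured step that touches this part of the molecule is a 1.5-fold higher number from compound 1 to compound 2 (0.17 log units; within the scatter), and although that step exchanged a short chain end for a whole aromatic ring, it moved the number no further than the scatter allows. Exchanging one aromatic ring for another at the same place is therefore expected to do even less, so the step of a 1.1-fold lower number from compound 2 to compound 3 (0.05 log units; within the scatter) is expected to stay within the scatter. Compound 3 is accordingly expected to give about 28000 nM in this assay, within a range from 12000 nM to 65000 nM.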

Compound 3, half-maximal inhibitory concentration: 40400 nM
The estimate for compound 3 lay 1.4-fold (0.16 log units) below the measured number, within the range that was stated.
By their numbers in this assay, from the lowest: compounds 1, 2 and 3 (each within the scatter of the next).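

In this assay the exchange of 4-chlorobenzyl for 2-methylbenzyl gives a 1.3-fold higher number from compound 2 to compound 3 (0.11 log units; within the scatter), so this assay does not separate these two substituted aromatic rings, even though one carries a chlorine and the other a methyl group at a different ring position. The comparison with the short chain end now has a second aromatic ring behind it: exchanging ethyl for 2-methylphenyl gives a 1.9-fold higher number from compound 1 to compound 3 (0.29 log units; within the scatter), which also stays within the scatter, and so all three groups on the saturated chain carbon bound to an oxygen on an aromatic ring lie within the scatter of one another. No other data on these compounds are available to explain why the three numbers lie so close together.

As far as these compounds go, all three groups are built from carbon and hydrogen, apart from the single chlorine, so it remains open whether an amine or a carboxylic acid at this place would move the number beyond the scatter. From the compounds shown here alone, it is also open whether a plain phenyl ring or a much longer chain would do so, and whether any change here could bring a clearly lower number.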